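The source may report more compounds than this note shows. Statements on the series, on what has been measured and on what is new or still open speak of the compounds shown alone.

Compound 1 `Cc1ccc(S/C(=C/c2ccc(F)c(C)c2)C(=O)c2ccc(Br)cc2)cc1` and compound 2 `Cc1ccc(S/C(=C/c2c[nH]c3ccc(Br)cc23)C(=O)c2ccc(Br)cc2)cc1` share a core in which a sulfur-linked aryl group and a bromophenyl ketone sit on a two-carbon double bond, and they differ in the aromatic group on the far carbon of that double bond. In a functional assay on DU-145 cells (Homo sapiens) for inhibition, read by trypan blue exclusion, with a stated time of 96 h (a higher number here means a weaker inhibitor of growth, a lower number a stronger inhibitor of growth), compound 1 gives 25000 nM, the higher of the two numbers recorded, while compound 2 gives 1000 nM, a gap well beyond the usual scatter of this assay.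

Compound 3 `CC(=O)c1ccc(/C=C(/Sc2ccc(C)cc2)C(=O)c2ccc(Br)cc2)cc1` has not yet been measured. It differs from compound 1 at one place: 4-acetylphenyl in place of 4-fluoro-3-methylphenyl on a double-bonded chain carbon bound to a double-bonded chain carbon. For the measured compounds named here, no measured pair shows this particular exchange, so its effect can only be guessed. Compound 2 shows that changing this aromatic group can move the number a long way, but compound 3 keeps a single six-membered carbon ring, as compound 1 does. A modest move toward a lower number, of uncertain size, is the expectation here; the step of a 2.1-fold lower number from compound 1 to compound 3 (0.32 log units; beyond the scatter) is an estimate. For compound 3 in this assay the expected value is 12000 nM, with a plausible range from 3000 nM to 40000 nM.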

Compound 3, concentration for 50% growth inhibition: 50000 nM
Compound 3: the middle estimate sits 4.2-fold (0.62 log units) below what was measured; measured number above the stated range.
By their numbers in this assay, from the lowest: compound 2; then compounds 1 and 3 (each within the scatter of the next).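

In this assay, placing 4-acetylphenyl in place of 4-fluoro-3-methylphenyl on a double-bonded chain carbon bound to a double-bonded chain carbon gives a step that cannot be told apart from the usual scatter (a 2.0-fold higher number from compound 1 to compound 3 (0.30 log units; within the scatter)). For the compounds shown here, the first two compounds showed only that the number can differ widely with the aromatic group at this position, whereas this pair shows two different substituted six-membered carbon rings that the assay does not separate, even though 4-acetylphenyl carries a hydrogen-bond acceptor and 4-fluoro-3-methylphenyl carries none. No independent measurement here bears on why the two groups read alike, so the result stands as an observation only.

On these data alone, it remains open which feature of the aromatic group in compound 2, which gives 1000 nM, goes with its lower number, since that group differs from the other two in several ways at once. The compounds shown also leave open how a six-membered carbon ring bearing an amine or a carboxylic acid would read at this position.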